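The source may report more compounds than this note shows. Statements on the series, on what has been measured and on what is new or still open speak of the compounds shown alone.

Of the compounds shown here, three built on one shared core have been tested in a functional assay on HepG2 cells (Homo sapiens) for antiproliferative activity, read by MTT assay, with a stated time of 48 h; on this read-out lower numbers stand for an effect already at smaller amounts and higher numbers for an effect only at larger amounts of compound. Compound 1 `Cc1ccccc1C(=O)Nc1nnc(-c2ccc3c(c2)OCCO3)s1` reaches only a limit of this assay, > 100 ug/mL; that limit is the limit of > 100 ug/mL in this assay, at which 1 of the 3 values shown sits. Compound 2 `O=C(CCc1ccccc1)Nc1nnc(-c2ccc3c(c2)OCCO3)s1` gives 15.3 ug/mL, and compound 3 `O=C(Nc1nnc(-c2ccc3c(c2)OCCO3)s1)c1ccc(Cl)nc1` gives 15.4 ug/mL. Of the two measured numbers, compound 3 carries the higher one, yet the step of a 1.0-fold higher number from compound 2 to compound 3 (0.00 log units; within the scatter) lies within the scatter, so the two compounds cannot be separated. The step of an at least 6.4-fold lower number from compound 1 to compound 3 (0.81 log units; beyond the scatter) is the only one here that goes beyond the scatter.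

Compound 4 `O=C(Nc1nnc(-c2ccc3c(c2)OCCO3)s1)c1ccccn1` is the untested member. It differs from compound 3 by pyridin-2-yl in place of 6-chloropyridin-3-yl on a carbonyl carbon. Among the measured compounds shown here, no measured step exchanges one pyridinyl group for another. The closest guide is a 1.0-fold higher number from compound 2 to compound 3 (0.00 log units; within the scatter), where a flexible phenethyl chain was replaced by the 6-chloropyridin-3-yl group without any change beyond the scatter, while an at least 6.4-fold lower number from compound 1 to compound 3 (0.81 log units; beyond the scatter) shows that altering the aromatic group on the carbonyl carbon can move the number well beyond the scatter. The present change is therefore expected to give a 1.6-fold higher number from compound 3 to compound 4 (0.21 log units; within the scatter). For compound 4 the estimate is 25 ug/mL, with an expected range from 8 ug/mL to 80 ug/mL.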

Compound 4, half-maximal effective concentration: > 100 ug/mL
Compound 4: only a limit was reported; the forecaster's own chance of this, stated with the estimate: 25%; middle value at least 4.0-fold (0.60 log units) away from the limit.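

The result shows that sharing a ring type does not guarantee a similar read-out at this position: 6-chloropyridin-3-yl and pyridin-2-yl are both six-membered aromatic rings with 1 hetero atom, yet exchanging them on the carbonyl carbon gives an at least 6.4-fold higher number from compound 3 to compound 4 (0.81 log units; beyond the scatter). The flexible phenethyl group also differs clearly from pyridin-2-yl here, with an at least 6.5-fold higher number from compound 2 to compound 4 (0.81 log units; beyond the scatter), so a pyridinyl group at this position can give either a measurable number or a limit. In this assay compound 4 reaches a limit, as compound 1 does, so the step between these two cannot be read: the limit of > 100 ug/mL in this assay, at which 2 of the 4 values shown sit.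

The chlorine and the ring's point of attachment both differ in this change, and the compounds shown do not separate their contributions. On these data alone, it also remains open how an amine or a methoxy group in place of the chlorine would behave.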